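Compound 3 and the swap of quinolin-2-yl

A few compounds are considered here, and "the series" means these few. Any claim that something is new, unique, unknown or untested is made for them only; others in the source may bear on it.

Values in a physicochemical assay for lipophilicity (on this read-out higher numbers stand for higher lipophilicity and lower numbers for lower lipophilicity), so far:
compound 1 `O=C(Nc1ccccc1Cl)N1CCN(c2nc(-c3ccc4ccccc4n3)no2)CC1` gives 2.95
compound 2 `O=C(NC1CCCCC1)N1CCN(c2nc(-c3ccc4ccccc4n3)no2)CC1` gives 2.76

In this assay compound 2 stands at 2.76, within the scatter of compound 1. Compound 3 `Cn1c(-c2noc(N3CCN(C(=O)NC4CCCCC4)CC3)n2)nc2ccccc21` differs from it in one place: 1-methyl-1H-benzimidazol-2-yl in place of quinolin-2-yl on an aromatic carbon, with 1-methyl-1H-benzimidazol-2-yl in place of quinolin-2-yl on an aromatic carbon. Among the measured compounds shown here, the only measured step, a number 0.19 log units lower from compound 1 to compound 2 (within the scatter), lies at an amide-type nitrogen rather than at this place, so it offers little guidance. With nothing measured here, only a modest downward move is expected, and the expected step is a number 0.31 log units lower from compound 2 to compound 3 (beyond the scatter). The estimate for compound 3 is 2.45, ranging from 2 to 2.9.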

Compound 3, distribution coefficient: 2.57
The estimate for compound 3 lay 0.12 log units below the measured number; the range from low to high includes it.
By their numbers in this assay, from the lowest: compounds 3, 2 and 1 (each within the scatter of the next, the first and the last beyond it).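

This is the first change shown at this position, on an aromatic carbon of the five-membered aromatic ring, and in this assay it gives a number 0.19 log units lower from compound 2 to compound 3 (within the scatter). In this one pair, 1-methyl-1H-benzimidazol-2-yl, with 2 hydrogen-bond acceptors, thus stands within the scatter of quinolin-2-yl, with 1. No measurement at hand accounts for this result. Going by these compounds, it remains open whether a carboxylic acid or an amine at this position would give a step beyond the scatter, and whether the same swap would read alike with 2-chlorophenyl on the amide-type nitrogen.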